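A few compounds are considered here, and "the series" means these few. Any claim that something is new, unique, unknown or untested is made for them only; others in the source may bear on it.

Measured compounds in the series:

- Compound 1, `Oc1ccccc1-c1cc(-c2ccccc2F)cc(-c2ccccc2O)n1`. In a functional assay on HeLa cells (Homo sapiens) for inhibition (a lower number here means a stronger inhibitor, a higher number a weaker inhibitor), compound 1 gives > 50000 nM, which is a limit of the assay and not a number.
- Compound 2, `Oc1ccccc1-c1cc(-c2cccc(F)c2)cc(-c2ccccc2O)n1`. In this assay compound 2 gives > 50000 nM, again a limit and not a number.

Compound 2 therefore stands at the limit of this assay, with nothing measured beyond it. Among the measured compounds shown here, the only measured step, a step that the two limits leave unreadable from compound 1 to compound 2, cannot be read in size because of the limit of > 50000 nM in this assay, at which 2 of the 2 values shown sit. For the measured compounds named here, no step of known size bears on the series.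

Compound 3, `Oc1ccccc1-c1cc(-c2ccc(F)cc2)cc(-c2ccccc2O)n1`, has not yet been measured in this assay. Its change from compound 2 is 4-fluorophenyl in place of 3-fluorophenyl on an aromatic carbon.

Going by the values given here, since both measured values in this assay sit at the limit, the change from compound 2 to compound 3 offers no measured step from which a direction could be taken. The expectation for compound 3 is accordingly that it will again return a limit, and the estimated step that the limit leaves unreadable from compound 2 to compound 3 is none beyond the scatter. The estimate for compound 3 in this assay is 60000 nM, within a range from 20000 nM to 300000 nM.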

Compound 3, half-maximal inhibitory concentration: > 50000 nM
Compound 3: no number, only a limit; the forecaster's own chance of this, stated with the estimate: 85%; the middle value is on the limit's open side.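

In this assay compound 3 gives > 50000 nM, a limit and not a number. The steps among compound 1, compound 2 and compound 3 therefore cannot be read in size, because all three share one limit: the limit of > 50000 nM in this assay, at which 3 of the 3 values shown sit.

The compounds shown leave open whether 2-fluorophenyl, 3-fluorophenyl and 4-fluorophenyl differ at all in this assay.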